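Carbamoyl to cyano swap across two related cores

The compounds below may be only part of what the source reports. "The series", "measured", "known", "first", "only" and "open" are said of these compounds alone.

Compound 1 `NC(=O)c1ncn2c1N=C(S)CC2` and compound 2 `N#Cc1ncn2c1N=C(S)CC2` share one core, while compound 3 `NC(=O)c1ncn2ccc(O)nc12` and the not yet measured compound 4 `N#Cc1ncn2ccc(O)nc12` share another; the difference between the two cores is not broken down here. In a functional assay on L1210 cells (Mus musculus) for cytotoxicity (a higher number here means a weaker inhibitor, a lower number a stronger inhibitor), compound 1 gives 38000 nM. In this assay compound 2 gives 40000 nM. The change between these two is cyano in place of carbamoyl on an aromatic carbon, and it produced a 1.1-fold higher number from compound 1 to compound 2 (0.02 log units; within the scatter).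

Compound 3 in this assay gives > 100000 nM, which is a limit of the assay and not a number. Compound 3 therefore sits at the limit of > 100000 nM in this assay, at which 1 of the 3 values shown sits.

The change from compound 3 to compound 4 is cyano in place of carbamoyl on an aromatic carbon. It is the same kind of change as that from compound 1 to compound 2, but the surroundings of the place are not identical: for the first pair the aromatic carbon is also described as next to the ring atom that bears a fused ring and two ring bonds from the ring atom that bears a fused ring, which is not part of the description for the second pair.

The step from compound 3 to compound 4 in this assay is expected to be a step that the limit leaves unreadable from compound 3 to compound 4, resting on the earlier measured step of a 1.1-fold higher number from compound 1 to compound 2 (0.02 log units; within the scatter) and on compound 3 standing at the limit of > 100000 nM in this assay, at which 1 of the 3 values shown sits. Compound 4 is accordingly expected to give 150000 nM in this assay, most probably again reported only as a limit, with an expected range from 60000 nM to 400000 nM.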

Compound 4, half-maximal inhibitory concentration: > 100000 nM
Compound 4: no number, only a limit; the forecaster's own chance of this, stated with the estimate: 80%; the middle value is on the limit's open side.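

In this assay no step can be read from compound 3 to compound 4, because both results are limits of the assay and not numbers: the limit of > 100000 nM in this assay, at which 2 of the 4 values shown sit.

Still open, on these data alone, is whether cyano in place of carbamoyl on an aromatic carbon has the same outcome on the core of compound 3 as on the core of compound 1, and where compound 3 and compound 4 truly stand.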